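A few compounds are considered here, and "the series" means these few. Any claim that something is new, unique, unknown or untested is made for them only; others in the source may bear on it.

Measured in a functional assay on DU-145 cells (Homo sapiens) for inhibition, read by MTT assay, with a stated time of 72 h; a higher number here means a weaker inhibitor, a lower number a stronger inhibitor:
- compound 1 `O=C1C=C(N2CCN(c3cccc(Cl)c3)CC2)C(=O)c2ccccc21`: 8300 nM
- compound 2 `Cc1cccc(N2CCN(C3=CC(=O)c4ccccc4C3=O)CC2)c1`: 7400 nM
- compound 3 `COc1cccc(N2CCN(C3=CC(=O)c4ccccc4C3=O)CC2)c1`: 15000 nM

Compound 3 stands close to compound 1, with a 1.8-fold higher number from compound 1 to compound 3 (0.26 log units; within the scatter). Its gap to compound 2 is slightly larger, with a 2.0-fold higher number from compound 2 to compound 3 (0.31 log units; beyond the scatter). Compound 4 `COc1cc(OC)cc(N2CCN(C3=CC(=O)c4ccccc4C3=O)CC2)c1` has not yet been measured. It keeps all of compound 3 and differs by methoxy in place of hydrogen on an aromatic carbon, meta to a large group and meta to a methoxy group.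

Among the measured compounds shown here, no measured step replaces a hydrogen with a group, so the evidence is indirect. The nearest guides are the exchanges among the three substituents. Methyl in place of chloro gave a 1.1-fold lower number from compound 1 to compound 2 (0.05 log units; within the scatter), methoxy in place of chloro gave a 1.8-fold higher number from compound 1 to compound 3 (0.26 log units; within the scatter), and methoxy in place of methyl gave a 2.0-fold higher number from compound 2 to compound 3 (0.31 log units; beyond the scatter). All three are small, and only the last lies beyond the scatter. Both steps that introduce methoxy point towards a higher number, which gives a weak hint of direction from these few compounds. A small step towards a higher number in this assay is therefore expected, probably not clearly beyond the scatter.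

The expected step is a 1.2-fold higher number from compound 3 to compound 4 (0.08 log units; within the scatter). Compound 4 is estimated at 18000 nM, with an expected range from 8000 nM to 40000 nM.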

Compound 4, half-maximal inhibitory concentration: 14900 nM
The estimate for compound 4 lay 1.2-fold (0.08 log units) above the measured number; measured number inside the range.
By their numbers in this assay, from the lowest: compounds 2, 1, 4 and 3 (each within the scatter of the next, the first and the last beyond it).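

In this assay, the methoxy that enters on an aromatic carbon, meta to a large group and meta to a methoxy group, gives a 1.0-fold lower number from compound 3 to compound 4 (0.00 log units; within the scatter), so compound 3 and compound 4 cannot be told apart. Among the compounds shown here, the earlier steps only exchanged one substituent for another at a single place on the ring, whereas this is the first step in which a group takes the place of a hydrogen, and here the added methoxy leaves the number where it stood. No measurement shown here offers an explanation for this result.

The compounds shown leave open whether this position would read the same with a group of another kind, such as an amine, a carboxylic acid or a longer chain such as butoxy, since methoxy is the only group seen there. They also leave open whether a methoxy at this position would give the same result with chloro or methyl in place of the methoxy already on the ring, as the step has been read only with that one partner.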